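The source may report more compounds than this note shows. Statements on the series, on what has been measured and on what is new or still open speak of the compounds shown alone.

Compound 1 `N#C[Se]Cc1ccc([N+](=O)[O-])cc1` and compound 2 `N#C[Se]Cc1cccc([N+](=O)[O-])c1` share the same atoms joined differently; the difference between the two cores is not broken down here. In an ADME assay on THP-1 cells (Homo sapiens) for cytotoxicity, read by trypan blue exclusion, with a stated time of 24 h (on this read-out lower numbers stand for stronger inhibition and higher numbers for weaker inhibition), compound 1 gives 16800 nM, and compound 2 gives 9320 nM. Compound 3 `N#C[Se]Cc1ccc(C#N)cc1` differs from compound 1 by cyano in place of nitro on an aromatic carbon, and in this assay compound 3 gives 7970 nM, which is a 2.1-fold lower number from compound 1 to compound 3 (0.32 log units; beyond the scatter). Compound 4 `N#C[Se]Cc1cccc(C#N)c1` has not yet been measured. It differs from compound 2 by cyano in place of nitro on an aromatic carbon, the same kind of change as before, here sitting meta rather than para to a group of 4 heavy atoms. In this assay compound 4 is expected to give about 5000 nM, within a range from 2500 nM to 10000 nM. That expectation rests on a 2.1-fold lower number from compound 1 to compound 3 (0.32 log units; beyond the scatter) and amounts to an estimated step of a 1.9-fold lower number from compound 2 to compound 4 (0.27 log units; within the scatter).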

Compound 4, half-maximal inhibitory concentration: 7600 nM
Beside the measured number, compound 4's estimate is 1.5-fold (0.18 log units) below it; the measured number falls inside the stated range.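

In this assay, cyano in place of nitro on the core of compound 2 gives a 1.2-fold lower number from compound 2 to compound 4 (0.09 log units; within the scatter) and so cannot be told apart from no change on this core. The two cores do not differ measurably in their response to this change: the same change on two cores in this assay, a 2.1-fold lower number (0.32 log units; beyond the scatter) from compound 1 to compound 3 and a 1.2-fold lower number (0.09 log units; within the scatter) from compound 2 to compound 4, 1.7-fold (0.24 log units) apart, within the scatter of two such steps. Among these compounds, this fits a change that carries from one core to the other, but it does not show that the step has the same size on both, as only two pairs are available and one stays within the scatter.

The compounds shown leave open how an amine or a carboxylic acid in place of nitro or cyano would compare. They also leave open whether the same step would appear with a longer chain on the ring.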